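The compounds below may be only part of what the source reports. "The series", "measured", "known", "first", "only" and "open" are said of these compounds alone.

Measured compounds:
- Compound 1 `COc1cccc(/C=C/C(=O)c2sc(Nc3cccc(C)c3)nc2C)c1`: in a functional assay on NCI-H460 cells (Homo sapiens) for cytotoxicity, read by MTT assay (a higher number here means a weaker inhibitor, a lower number a stronger inhibitor), compound 1 gives only a limit, > 25000 nM.
- Compound 2 `Cc1cccc(Nc2nc(C)c(C(=O)/C=C/c3ccccc3)s2)c1`: in this assay compound 2 gives 21800 nM.
- Compound 3 `COc1cccc(/C=C/C(=O)c2sc(Nc3ccc(C)cc3)nc2C)c1`: in this assay compound 3 gives only a limit, > 25000 nM.

Going by the values given here, two of the three values sit at the same limit, (the limit of > 25000 nM in this assay, at which 2 of the 3 values shown sit), so compound 2 is the only one with a number. Among the compounds with values here, the one change that can be read at all is hydrogen in place of methoxy on an aromatic carbon; its step is an at least 1.1-fold lower number from compound 1 to compound 2 (0.05 log units; that floor lies within the scatter), with the lower end of that step lying within the scatter. The two cores differ by 4-methylphenyl in place of 3-methylphenyl on a nitrogen on an aromatic ring; the step that the two limits leave unreadable from compound 1 to compound 3 cannot be sized.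

Compound 4 `Cc1ccc(Nc2nc(C)c(C(=O)/C=C/c3ccccc3)s2)cc1` is not yet measured. Its difference from compound 3 is hydrogen in place of methoxy on an aromatic carbon. The place given for this change matches word for word the place given for the change from compound 1 to compound 2, so it is the same change made on the other core. No further information on this core is available beyond what compound 3 shows. The expectation for compound 4 therefore rests on what the same change did from compound 1 to compound 2 and on compound 2 giving 21800 nM in this assay. The step from compound 3 to compound 4 in this assay is therefore expected to be small, an at least 1.0-fold lower number from compound 3 to compound 4 (0.03 log units; that floor lies within the scatter), and since compound 3 is only a limit the result may again be reported as a limit. For compound 4 the estimate is 23000 nM, with a range from 11000 nM to 50000 nM.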

Compound 4, half-maximal inhibitory concentration: > 25000 nM
Compound 4: no number, only a limit; the forecaster's own chance of this, stated with the estimate: 50%; middle value at least 1.0-fold (0.03 log units) from the limit.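

In this assay compound 4 gives only a limit, > 25000 nM, so the change from 3-methoxyphenyl to phenyl cannot be read on the core of compound 3 and cannot be set against the same change on the core of compound 1: the limit of > 25000 nM in this assay, at which 3 of the 4 values shown sit.

With the phenyl group kept, putting 4-methylphenyl in place of 3-methylphenyl gives an at least 1.1-fold higher number from compound 2 to compound 4 (0.05 log units; that floor lies within the scatter), so a difference between these two groups is not established, although a larger one is not excluded. The change yields a number on one core, in compound 2, and only a limit on the other, in compound 4, but this shows neither that it acts differently on the two cores nor that it acts alike.

Open is whether any compound in this series can give a number well clear of the limit, since compound 2 is the only one shown with a number at all. Also open, on these data alone, is how the series reads with an amine or a carboxylic acid in place of the methoxy, or with a longer chain in place of the methyl on the 4-methylphenyl group.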